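From Naphthalen-1-yl to 4-Fluorophenyl: An Expected Recovery

This account rests on a few compounds, and the source may have more. Where it says the series, first, only, none or still open, it means among the compounds named here.

Two members of the series have been measured in a functional assay on DU-145 cells (Homo sapiens) for inhibition, read by sulforhodamine B assay, with a stated time of 48 h, tested at 10 uM; a higher number here means more inhibition at the concentration tested (going by the name of the read-out), a lower number less inhibition. Compound 1 `COc1ccc(-c2cn3ccnc3c(-c3ccc4ncn(C5CCCCC5)c4c3)n2)cc1` carries a 4-methoxyphenyl group and gives 81.8%. Compound 2 `c1ccc2c(-c3cn4ccnc4c(-c4ccc5ncn(C6CCCCC6)c5c4)n3)cccc2c1` carries a naphthalen-1-yl group on the same aromatic carbon and gives 5.1%; of the two numbers it is the lowest, and its nearest neighbour, compound 1, sits far above it, beyond the scatter. Within the data shown here, the only step measured so far is a number 76.7 percentage points lower from compound 1 to compound 2 (beyond the scatter).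

Compound 3 `Fc1ccc(-c2cn3ccnc3c(-c3ccc4ncn(C5CCCCC5)c4c3)n2)cc1` differs from compound 2 in one place: 4-fluorophenyl in place of naphthalen-1-yl on an aromatic carbon. Among the measured compounds shown here, only the step from compound 1 to compound 2 bears on this change, and it shows that putting naphthalen-1-yl in place of 4-methoxyphenyl lost a large share of the inhibition. Going back from naphthalen-1-yl to a phenyl bearing a single fluorine is therefore expected to recover much of it, although 4-fluorophenyl is not 4-methoxyphenyl and no step between those two groups has been measured. Compound 3 is thus estimated to give 65% in this assay, within 30% to 90%. This corresponds to an expected step of a number 59.9 percentage points higher from compound 2 to compound 3 (beyond the scatter).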

Compound 3, a percentage reported as inhibition, at one concentration (the size of the read-out at that concentration, not a potency): 1.17%
Beside the measured number, compound 3's estimate is 63.8 percentage points above it, and the stated range ends above it.
By their numbers in this assay, from the lowest: compounds 3 and 2 (each within the scatter of the next); then compound 1.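

In this assay, 4-fluorophenyl in place of naphthalen-1-yl on this aromatic carbon gives a number 3.9 percentage points lower from compound 2 to compound 3 (within the scatter), so the two groups cannot be told apart here, and the low number of compound 2 is not confined to a group with two aromatic rings. Fluoro in place of methoxy on the phenyl ring gives a number 80.6 percentage points lower from compound 1 to compound 3 (beyond the scatter), which shows that a single-ring aryl group on this carbon does not by itself keep the inhibition, and that exchanging that one substituent is enough to take away nearly all of the inhibition seen with compound 1. None of the information at hand accounts for this difference between methoxy and fluoro.

The three compounds leave open whether methoxy is singular in this respect, or whether a phenyl ring carrying ethoxy, hydroxy or an amine in its place would side with compound 1 or with compound 3. They also leave open where an unsubstituted phenyl group would fall, and whether the same exchange would give a step of this size with a group other than cyclohexyl on the far side of the core.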